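Lactone Ring Replaced by Dioxane on a Thioether Linker

A few compounds are considered here, and "the series" means these few. Any claim that something is new, unique, unknown or untested is made for them only; others in the source may bear on it.

Measured compounds:
compound 1, `C[C@@]1(O)CC(=O)OC(CSc2nc(-c3ccccc3)c(-c3ccccc3)[nH]2)C1`, 170 nM
compound 2, `O=C1CCCC(CSc2nc(-c3ccccc3)c(-c3ccccc3)[nH]2)O1`, 740 nM
compound 3, `CC1(C)CC(=O)OC(CSc2nc(-c3ccccc3)c(-c3ccccc3)[nH]2)C1`, 100 nM

In an assay on microsomes from liver for inhibition of sterol O-acyltransferase 1 (Rattus norvegicus) (on this read-out lower numbers stand for stronger inhibition and higher numbers for weaker inhibition), compound 3 gives the lowest of the three numbers, but its distance to compound 1 is within the scatter, so only compound 2 stands clearly apart from it: a 7.4-fold lower number from compound 2 to compound 3 (0.87 log units; beyond the scatter). The other steps are a 4.4-fold higher number from compound 1 to compound 2 (0.64 log units; beyond the scatter) and a 1.7-fold lower number from compound 1 to compound 3 (0.23 log units; within the scatter).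

Compound 4, `c1ccc(-c2nc(SCCC3OCCCO3)[nH]c2-c2ccccc2)cc1`, is the one still to be measured. Relative to compound 3 it shows (a group of 7 heavy atoms (5 carbon, 2 oxygen; one six-membered non-aromatic ring with 2 hetero atoms) in place of a group of 9 heavy atoms (7 carbon, 2 oxygen; one six-membered non-aromatic ring with 1 hetero atom), on a saturated chain carbon bound to a sulfur). Among the compounds with values here, the step from compound 2 to compound 3 bears on this, since it is the only measured change that alters the carbon and oxygen make-up of that ring, and it was modest in size. The dioxane ring of compound 4 keeps the two oxygens of the ring it replaces but loses the double bond outside aromatic rings, so a modest rise in this assay is expected rather than none, with a 6.0-fold higher number from compound 3 to compound 4 (0.78 log units; beyond the scatter). Compound 4 is therefore estimated at 600 nM, with a range from 200 nM to 2000 nM.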

Compound 4, half-maximal inhibitory concentration: 730 nM
For compound 4 the middle estimate is 1.2-fold (0.09 log units) below the measured one, within the range that was stated.
By their numbers in this assay, from the lowest: compounds 3 and 1 (each within the scatter of the next); then compounds 4 and 2 (each within the scatter of the next).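

In this assay the dioxane of compound 4, on a saturated chain carbon bound to a sulfur, gives a 7.3-fold higher number from compound 3 to compound 4 (0.86 log units; beyond the scatter) and also a 4.3-fold higher number from compound 1 to compound 4 (0.63 log units; beyond the scatter), so it stands clearly apart from both groups of 9 heavy atoms. Against the other group of 7 heavy atoms the result is a 1.0-fold lower number from compound 2 to compound 4 (0.01 log units; within the scatter), so a ring with 2 hetero atoms and no double bond outside aromatic rings reads the same here as a ring with 1 hetero atom and such a double bond. Across these four compounds the numbers therefore follow the heavy-atom count of the group, and none of them goes against this.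

No evidence on hand gives a reason for this pattern. The compounds shown leave open how an amine or a carboxylic acid on the ring, or a longer chain carrying the dioxane, would read in this assay.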